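Pyridine amides in the cytotoxicity series: notes toward compound 4

The source may report more compounds than this note shows. Statements on the series, on what has been measured and on what is new or still open speak of the compounds shown alone.

Measured so far:
compound 1 `O=C(Nc1cc(C(F)(F)F)ccc1N1CCCC1)c1ccncc1`, "not active" (no number reported)
compound 2 `O=C(Nc1cc(C(F)(F)F)ccc1NC1CCCCC1)c1cccnc1`, "not active" (no number reported)
compound 3 `O=C(Nc1cc(C(F)(F)F)ccc1Nc1ccc(Br)cc1)c1cccnc1Cl`, 20600 nM
compound 4 `O=C(Nc1cc(C(F)(F)F)ccc1Nc1ccc(Br)cc1)c1ccncc1`, not yet measured

For the measured compounds named here, in a functional assay on Jurkat cells (Homo sapiens) for cytotoxicity, read by MTT assay, with a stated time of 48 h (a higher number here means a weaker inhibitor, a lower number a stronger inhibitor), compound 3 is the only member of the series with a reported number, and that number is a weak one. Going by the values given here, compound 1 and compound 2 were reported without a number in this assay, so no step between measured compounds can be drawn, and compound 3 stands alone as the reference point.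

Compound 4 keeps the whole of compound 3 apart from one change on the carbonyl carbon: pyridin-4-yl in place of 2-chloropyridin-3-yl on a carbonyl carbon. Compound 1, which also carries a pyridin-4-yl carbonyl on a differently substituted core, gave "not active" (no number reported) in this assay, which gives no numerical guidance but offers no encouragement either.

Among the compounds with values here, with no step in hand, only a loosely held expectation can be set. The step from compound 3 to compound 4 is expected to be small or toward weaker inhibition, a 1.5-fold higher number from compound 3 to compound 4 (0.16 log units; within the scatter), with a real chance that no number is returned. Compound 4 is expected to give about 30000 nM in this assay, within a range of 10000 nM to 100000 nM.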

Compound 4, half-maximal inhibitory concentration: "not active" (no number reported)
Nothing numeric was reported for compound 4, and the estimate cannot be compared.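

For the compounds shown here, compound 4 returned no number in this assay, so no step from compound 3 to compound 4 can be read, and no measured evidence bears on this result. The compounds shown leave open whether any pyridin-4-yl amide in this series can return a number.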